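Benzamide series on the shared core: arylamino replaces piperidine

A few compounds are considered here, and "the series" means these few. Any claim that something is new, unique, unknown or untested is made for them only; others in the source may bear on it.

Measured in a functional assay on HepG2 cells (Homo sapiens) for antiproliferative activity, read by CCK-8 assay, with a stated time of 72 h; on this read-out lower numbers stand for stronger inhibition and higher numbers for weaker inhibition:
Compound 1 `CN1CCN(c2nc(Cl)nc3c2ncn3Cc2ccc(C(=O)Nc3ccccc3N)cc2)CC1`: 2010 nM
Compound 2 `Nc1ccccc1NC(=O)c1ccc(Cn2cnc3c(Nc4ccc(-c5ccccn5)cc4)nc(Cl)nc32)cc1`: 30100 nM
Compound 3 `CC1CCN(c2nc(Cl)nc3c2ncn3Cc2ccc(C(=O)Nc3ccccc3N)cc2)CC1`: 5180 nM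

Compound 3 stands second highest of the three numbers; in this assay compound 1 gives 2010 nM and compound 2 gives 30100 nM. Going by the values given here, the only one-place step measured is a 2.6-fold higher number from compound 1 to compound 3 (0.41 log units; beyond the scatter). Compound 4 `Nc1ccccc1NC(=O)c1ccc(Cn2cnc3c(Nc4cccc(Cl)c4)nc(Cl)nc32)cc1` differs from compound 3 by (3-chlorophenyl)amino in place of 4-methylpiperidin-1-yl on an aromatic carbon. Among the compounds with values here, no measured step covers this change directly; compound 2, which also carries an arylamino group at that position, shows the highest number of the series, so compound 4 is expected to move the same way, with a step of a 2.9-fold higher number from compound 3 to compound 4 (0.46 log units; beyond the scatter) in this assay. For compound 4 the estimate is 15000 nM, in the range 5000 nM to 45000 nM.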

Compound 4, half-maximal inhibitory concentration: 9800 nM
Compound 4: middle estimate off by 1.5-fold (0.18 log units), on the high side, and the stated range covers the measured number.
By their numbers in this assay, from the lowest: compound 1; then compounds 3 and 4 (each within the scatter of the next); then compound 2.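

In this assay, the (3-chlorophenyl)amino group cannot be told apart from 4-methylpiperidin-1-yl at this position: a 1.9-fold higher number from compound 3 to compound 4 (0.28 log units; within the scatter) stays within the scatter, whereas against 4-methylpiperazin-1-yl, a 4.9-fold higher number from compound 1 to compound 4 (0.69 log units; beyond the scatter) lies beyond it. An arylamino group therefore does not by itself give a number as high as that of compound 2, since 3-chlorophenyl in place of 4-(pyridin-2-yl)phenyl on the nitrogen gives a 3.1-fold lower number from compound 2 to compound 4 (0.49 log units; beyond the scatter). No evidence available here bears on these steps.

Still open, on these data alone, is how morpholin-4-yl would compare with 4-methylpiperazin-1-yl at this position. As far as these compounds go, the effect of moving the chlorine on the phenyl ring, or of replacing it with methoxy, also remains open.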